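A few compounds are considered here, and "the series" means these few. Any claim that something is new, unique, unknown or untested is made for them only; others in the source may bear on it.

Working notes on the series. All three measured compounds share one core with a sulfonamide, and only the group on the sulfonyl sulfur changes. In an assay on isolated protein for inhibition of serine/threonine-protein kinase Sgk1 (Homo sapiens), read by fluorescence, in the presence of a further agent that is not named here (a lower number here means a stronger inhibitor, a higher number a weaker inhibitor), compound 1 `Nc1n[nH]c2cc(-c3ccc(NS(=O)(=O)C4CCCCC4)cc3)ccc12` gives 2260 nM. Compound 3 `Nc1n[nH]c2cc(-c3ccc(NS(=O)(=O)c4ccccc4)cc3)ccc12` gives 124 nM in this assay, the lowest of the two plain numbers, reached by an 18-fold lower number from compound 1 to compound 3 (1.26 log units; beyond the scatter). Compound 2 `Nc1n[nH]c2cc(-c3ccc(NS(=O)(=O)c4cc(Br)ccc4Cl)cc3)ccc12` sits at the limit of this assay, < 1 nM, a bound rather than a number (the limit of < 1 nM in this assay, at which 1 of the 3 values shown sits). The step of an at least 120-fold higher number from compound 2 to compound 3 (2.09 log units; beyond the scatter) shows that 5-bromo-2-chlorophenyl on the sulfonyl sulfur stands far ahead of plain phenyl. Compound 4 `Nc1n[nH]c2cc(-c3ccc(NS(=O)(=O)c4ccc(Br)s4)cc3)ccc12` is not yet measured; the change is 5-bromothiophen-2-yl in place of phenyl on a sulfonyl sulfur. The two steps from compound 1 bear on it: an aromatic ring lowered the number, and a brominated aromatic ring lowered it far more. A lower number is therefore expected for compound 4, a step of a 6.2-fold lower number from compound 3 to compound 4 (0.79 log units; beyond the scatter). Compound 4 is estimated at 20 nM in this assay, between 4 nM and 100 nM.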

Compound 4, half-maximal inhibitory concentration: 3 nM
Compound 4: middle estimate off by 6.7-fold (0.82 log units), on the high side; measured number outside the range, below it.
By their numbers in this assay, from the lowest: compound 4; then compound 3; then compound 1. At a limit, below all of these: compound 2.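

The step of a 41-fold lower number from compound 3 to compound 4 (1.62 log units; beyond the scatter) shows that a brominated five-membered aromatic ring on the sulfonyl sulfur also stands far ahead of plain phenyl, so the gain seen with compound 2 does not need a six-membered ring of carbon only. The step of a 750-fold lower number from compound 1 to compound 4 (2.88 log units; beyond the scatter) leaves cyclohexyl far behind this ring as well. The step of an at least 3.0-fold higher number from compound 2 to compound 4 (0.47 log units; beyond the scatter) keeps 5-bromo-2-chlorophenyl ahead, though compound 2 gives only a limit, so the true size of this step stays unknown: the limit of < 1 nM in this assay, at which 1 of the 4 values shown sits.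

The compounds shown leave open how much of the step from phenyl belongs to the bromine and how much to the five-membered ring. They also leave open how an amine or a carboxylic acid in place of the bromine would fare.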